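The source may report more compounds than this note shows. Statements on the series, on what has been measured and on what is new or still open speak of the compounds shown alone.

Measured so far:
Compound 1 `O=C(NCc1ccc(Cl)cc1Cl)[C@@H]1CCC(=O)N1c1ccco1`: 575 nM
Compound 2 `O=C(NCc1ccc(Cl)cc1Cl)[C@@H]1CCC(=O)N1c1ccoc1`: 422 nM

In an assay on HEK293 cells for displacement of a labelled ligand from P2X purinoceptor 7 (Homo sapiens), read by scintillation counting, with a stated time of 1 h (a higher number here means a weaker inhibitor, a lower number a stronger inhibitor), compound 1 gives 575 nM. In this assay, among the compounds with values here, compound 2 gives 422 nM, the lower of the two numbers, though the only measured step, a 1.4-fold lower number from compound 1 to compound 2 (0.13 log units; within the scatter), lies within the scatter, so the two compounds cannot be ordered. Compound 3 `O=C(NCc1ccc(Cl)cc1Cl)[C@@H]1CCC(=O)N1c1cscn1` keeps the shared core of compound 2 and differs from it in one place: 1,3-thiazol-4-yl in place of furan-3-yl on an amide-type nitrogen in a ring. Within the data shown here, no measured step bears directly on this exchange; the single step that is known, a move between two attachment points of the same five-membered aromatic ring, changed the number by little. The account therefore expects no step beyond the scatter in this assay from this second ring exchange. Compound 3 is estimated to give 420 nM, with a range from 150 nM to 1200 nM. That expectation corresponds to a 1.0-fold lower number from compound 2 to compound 3 (0.00 log units; within the scatter).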

Compound 3, half-maximal inhibitory concentration: 384 nM
For compound 3 the middle estimate is 1.1-fold (0.04 log units) above the measured one; measured number inside the range.
By their numbers in this assay, from the lowest: compounds 3, 2 and 1 (each within the scatter of the next).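

In this assay, 1,3-thiazol-4-yl in place of furan-3-yl gives a 1.1-fold lower number from compound 2 to compound 3 (0.04 log units; within the scatter) and the same group in place of furan-2-yl gives a 1.5-fold lower number from compound 1 to compound 3 (0.18 log units; within the scatter). This shows that, on the amide-type nitrogen in a ring, a five-membered aromatic ring with 2 hetero atoms, one of them sulfur, stays within the scatter of both furans, whereas the earlier pair compared only two attachment points of a single ring, so the three compounds still cannot be ordered. No supporting measurement says why these rings read alike.

The compounds shown leave open what a six-membered pyridine ring, a saturated cyclohexyl ring or a plain ethyl chain would give at this place. They also leave open whether an amine or a carboxylic acid carried on the five-membered ring would produce a step beyond the scatter.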